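Side-chain exchange on the amide carbon of compound 1

This account rests on a few compounds, and the source may have more. Where it says the series, first, only, none or still open, it means among the compounds named here.

Measured so far:
compound 1 `NC(=O)CC[C@H](NC(=O)CN(c1ncnc2c1ncn2C1CCCCO1)C1CC1)C(=O)OCc1ccccc1`: 22.3%
compound 2 `O=C(OCc1ccccc1)[C@@H]1CCCN1C(=O)CN(c1nc(Cl)nc2[nH]cnc12)C1CC1`: 38.4%
compound 3 `O=C(CN(c1nc(Cl)nc2[nH]cnc12)C1CC1)N[C@@H](CC(=O)OCc1ccccc1)C(=O)OCc1ccccc1`: 12.1%

Of the compounds shown here, three have been tested in a functional assay on the whole organism (Tail, strain ICR) with Mus musculus as the target, in the tail flick test, with a stated time of 120 min, at a dose of 25 umol/kg by the oral route; a higher number here means a stronger effect of the compound at the dose given, a lower number a weaker effect. On these numbers compound 1 stands second highest of the three. Its nearest neighbour is compound 3, which sits lower by a margin beyond the usual scatter of such measurements; compound 2 lies furthest away, higher by a margin that is also beyond the scatter. For the measured compounds named here, compound 2 and compound 3 share a different core from compound 1, so no pair of measured compounds differs in a single place, and none of the measured steps isolates the change considered here.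

The next compound, compound 4 `CC[C@H](C)[C@H](NC(=O)CN(c1ncnc2c1ncn2C1CCCCO1)C1CC1)C(=O)OCc1ccccc1`, keeps the core of compound 1 and differs from it only in the side chain: sec-butyl in place of 2-carbamoylethyl on a saturated chain carbon bound to an amide-type nitrogen and a carbonyl carbon. Going by the values given here, nothing among the measured compounds speaks to how this exchange plays out in this assay. In the absence of such a reference, the step from compound 1 to compound 4 is expected to be small, about a number 2.7 percentage points higher from compound 1 to compound 4 (within the scatter), and not clearly beyond the scatter in either direction. Compound 4 is therefore estimated at 25%, with a plausible range from 10% to 42%.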

Compound 4, a percentage reported as activity, at one dose (the size of the read-out at that dose, not a potency): 20.4%
Compound 4: middle estimate off by 4.6 percentage points, on the high side, and the stated range covers the measured number.
By their numbers in this assay, from the lowest: compounds 3, 4 and 1 (each within the scatter of the next, the first and the last beyond it); then compound 2.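

In this assay the exchange of 2-carbamoylethyl for sec-butyl on a saturated chain carbon bound to an amide-type nitrogen and a carbonyl carbon amounts to a number 1.9 percentage points lower from compound 1 to compound 4 (within the scatter) and leaves the two compounds level on this read-out. For the compounds shown here, this is the first pair that differs in one place, and it shows that on the core of compound 1, at this one dose and time, a side chain with a hydrogen-bond donor and acceptor and a side chain with neither give numbers that cannot be told apart. No separate measurement bears on this result, so the level outcome stands without an explanation.

On these data alone, it remains open whether this position stays just as indifferent to other side chains, such as one ending in a carboxylic acid or an amine, or a longer chain than sec-butyl. Also open, as far as these compounds go, is whether the same exchange would read alike on the core shared by compound 2 and compound 3, or at another dose or time.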